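Estimating compound 4 from three measured analogues

The compounds below may be only part of what the source reports. "The series", "measured", "known", "first", "only" and "open" are said of these compounds alone.

Compound 1 `CCCc1nc(-c2ccccc2)c(CNCCCN2CCN(c3ccc(F)cc3)CC2)o1` gives 3210 nM in an assay on HEK293 cells for inhibition of Voltage-dependent T-type calcium channel subunit alpha-1G (Homo sapiens), read by patch clamp; on this read-out lower numbers stand for stronger inhibition and higher numbers for weaker inhibition.
Compound 2 `CCCc1nc(-c2ccccc2)c(CNCCN2CCN(c3cccc(C)c3C)CC2)o1` gives 1710 nM in this assay.
Compound 3 `CCCc1nc(-c2ccccc2)c(CNCCCN2CCN(c3ccc(C)cc3)CC2)o1` gives 130000 nM in this assay.

Compound 2 shows the lowest number of the three, but its gap to compound 1 lies within the scatter, so the two cannot be ranked against each other; compound 3 sits far behind both. Compound 4 `CCCc1nc(-c2ccccc2)c(CNCCN2CCN(c3ccccc3C(F)(F)F)CC2)o1` has not yet been measured. It differs from compound 2 in one place: 2-(trifluoromethyl)phenyl in place of 2,3-dimethylphenyl on an amine nitrogen in a ring.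

Within the data shown here, the only step measured between compounds that differ in a single place is a 40-fold higher number from compound 1 to compound 3 (1.61 log units; beyond the scatter), and it concerns the same aromatic ring on the ring nitrogen. That step shows that a change on this ring can move the number a great deal, with a fluorine-bearing group on the better side. Among the measured compounds shown here, still, no measured pair exchanges a 2,3-dimethylphenyl for a 2-(trifluoromethyl)phenyl, and the linker of compound 2 also differs from that of compound 1 and compound 3, so the step is only a loose guide.

The expected outcome is therefore a change of a 1.1-fold lower number from compound 2 to compound 4 (0.06 log units; within the scatter), within the scatter or close to it, in either direction. Compound 4 is estimated at 1500 nM, with a likely range from 300 nM to 8000 nM.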

Compound 4, half-maximal inhibitory concentration: 2100 nM
Beside the measured number, compound 4's estimate is 1.4-fold (0.15 log units) below it; the measured number falls inside the stated range.
By their numbers in this assay, from the lowest: compounds 2, 4 and 1 (each within the scatter of the next); then compound 3.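

Exchanging 2,3-dimethylphenyl for 2-(trifluoromethyl)phenyl on the amine nitrogen of the six-membered ring gives a 1.2-fold higher number from compound 2 to compound 4 (0.09 log units; within the scatter) in this assay, so the two compounds cannot be told apart on this read-out. The earlier step, a 40-fold higher number from compound 1 to compound 3 (1.61 log units; beyond the scatter), showed that a small exchange on this aromatic ring can matter greatly, whereas this pair shows that a larger exchange, from two methyl groups to one trifluoromethyl group and from 8 to 10 heavy atoms, can leave the number within the scatter. The two steps come from compounds with different chains, and no measurement shown accounts for the contrast between them.

Among these compounds, it remains open whether other groups on this aromatic ring, such as a methoxy group, a nitrile or a chlorine atom, would also give numbers close to those of compound 2 and compound 4, or would instead produce a large step like the one to compound 3. On these data alone, the effect of the chain joining the two amine nitrogens also remains open, as does whether 2-(trifluoromethyl)phenyl would behave the same way on the longer chain of compound 1.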